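This account rests on a few compounds, and the source may have more. Where it says the series, first, only, none or still open, it means among the compounds named here.

In a functional assay on MCF7 cells (Homo sapiens) for antiproliferative activity, read by MTT assay, with a stated time of 48 h (on this read-out higher numbers stand for weaker inhibition and lower numbers for stronger inhibition), compound 1 `O=C(/C=C/c1cn(S(=O)(=O)c2ccc([N+](=O)[O-])cc2)c2ccccc12)c1ccncc1` gives 14500 nM; "dose-dependent effect" (no number reported) (2 entries). Compound 2 `O=C(/C=C/c1cn(S(=O)(=O)c2cccc([N+](=O)[O-])c2)c2ccccc12)c1ccncc1` gives 36300 nM and compound 3 `O=C(/C=C/c1cn(S(=O)(=O)c2cccc3ccccc23)c2ccccc12)c1ccncc1` gives 58000 nM, both higher numbers than compound 1 shows. These two stand level within the scatter, with a 1.6-fold higher number from compound 2 to compound 3 (0.20 log units; within the scatter). Compound 4 `CCCS(=O)(=O)n1cc(/C=C/C(=O)c2ccncc2)c2ccccc21` is the next to be read, and it differs from compound 3 as follows: propyl in place of naphthalen-1-yl on a sulfonyl sulfur. That measured step is the only one at this sulfonyl sulfur, and it exchanged one aromatic group for another. Among the compounds with values here, no measured step removes the ring altogether, so the evidence is thin and no shift beyond the scatter is expected in this assay. The expected change is a 1.5-fold lower number from compound 3 to compound 4 (0.16 log units; within the scatter). Compound 4 is estimated at 40000 nM, within an expected range of 14000 nM to 110000 nM.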

Compound 4, half-maximal inhibitory concentration: 52400 nM
The estimate for compound 4 lay 1.3-fold (0.12 log units) below the measured number; measured number inside the range.
By their numbers in this assay, from the lowest: compounds 2, 4 and 3 (each within the scatter of the next).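

In this assay, propyl on the sulfonyl sulfur, which has no ring, stands level with both aromatic groups: a 1.1-fold lower number from compound 3 to compound 4 (0.04 log units; within the scatter) and a 1.4-fold higher number from compound 2 to compound 4 (0.16 log units; within the scatter). Among compounds 2, 3 and 4, then, a ring at this position makes no difference that can be read, while compound 1 shows a lower number, 14500 nM; "dose-dependent effect" (no number reported) (2 entries). Nothing measured here explains this result. On these data alone, it remains open whether a longer chain than propyl, or a chain ending in an amine or a carboxylic acid, would stay in this range.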